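A few compounds are considered here, and "the series" means these few. Any claim that something is new, unique, unknown or untested is made for them only; others in the source may bear on it.

Measured so far in a functional assay on the whole organism with Canis familiaris (Canis lupus familiaris) as the target, at a dose of 5 mg/kg by the intravenous route; on this read-out lower numbers stand for a weaker effect and higher numbers for a stronger effect at the one dose given:
Compound 1, `Cc1nc2c(CCc3ccccc3)nccn2c1N`, gives 18%.
Compound 2, `CNC(=O)Nc1c(C)nc2c(OCc3ccccc3)cccn12`, gives 27%.
Compound 3, `CCNc1c(C)nc2c(OCc3ccccc3)nccn12`, gives 0%.

Compound 2 holds the highest of the three numbers in this assay; its gap to compound 1 lies within the usual scatter of repeated measurements, while its gap to compound 3 lies beyond it. Compound 4, `COc1c(C)nc2c(OCc3ccccc3)cccn12`, differs from compound 2 in one place: methoxy in place of (methylcarbamoyl)amino on an aromatic carbon. A (methylcarbamoyl)amino group, carrying two hydrogen-bond donors, leaves and a methoxy group with none enters. For the measured compounds named here, no measured pair shows this change, so its effect can only be judged from the spread of the three numbers. The expected step from compound 2 to compound 4 is a modest fall, a number 12 percentage points lower from compound 2 to compound 4 (beyond the scatter), which may not exceed the scatter. Compound 4 is therefore estimated at 15%, within a range from 0% to 35%.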

Compound 4, a percentage reported as inhibition, in the whole organism at one dose (the size of the read-out at that dose, not a potency): 37%
For compound 4 the middle estimate is 22 percentage points below the measured one; the measured number lies above the stated range.
By their numbers in this assay, from the lowest: compound 3; then compounds 1, 2 and 4 (each within the scatter of the next, the first and the last beyond it).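

In this assay, putting methoxy in place of (methylcarbamoyl)amino on this aromatic carbon gives a number 10 percentage points higher from compound 2 to compound 4 (within the scatter). This single pair therefore shows that the effect at this dose holds up when a smaller group with no hydrogen-bond donors replaces the larger one, so the donors of the (methylcarbamoyl)amino group are not required here. Nothing available explains why the two compounds read alike. The compounds shown leave open how a hydroxyl or an ethoxy group at this aromatic carbon would read, and whether any group there could move the number beyond the scatter.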